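Compound 4: a new group where compound 3 gave no number

A few compounds are considered here, and "the series" means these few. Any claim that something is new, unique, unknown or untested is made for them only; others in the source may bear on it.

Compound 1 `O=C(N/N=C/c1cccc(Br)c1)Nc1ccc(Oc2ccnc3[nH]ccc23)c(F)c1` gives 4020 nM
Compound 2 `O=C(N/N=C/c1cccc([N+](=O)[O-])c1)Nc1ccc(Oc2ccnc3[nH]ccc23)c(F)c1` gives 5140 nM
Compound 3 `O=C(N/N=C/c1cccc(Cl)c1Cl)Nc1ccc(Oc2ccnc3[nH]ccc23)c(F)c1` gives "not active" (no number reported)

All three were tested in a functional assay on PC-3 cells (Homo sapiens) for antiproliferative activity, read by MTT assay, with a stated time of 72 h (on this read-out higher numbers stand for weaker inhibition and lower numbers for stronger inhibition), on the same shared core. Within the data shown here, compound 3 stands apart from the other two: it has no number, so no step from it can be sized. Compound 4 `O=C(N/N=C/c1ccc(O)cc1O)Nc1ccc(Oc2ccnc3[nH]ccc23)c(F)c1` carries 2,4-dihydroxyphenyl in place of 2,3-dichlorophenyl on a carbon with a double bond to nitrogen and the rest of the structure stays the same.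

Among the measured compounds shown here, only one measured step exists, a 1.3-fold higher number from compound 1 to compound 2 (0.11 log units; within the scatter) with nitro in place of bromo, and it stays within the scatter. It involves different groups, so it is only a loose guide. It offers no size or direction for the change from compound 3 to compound 4. A report of not active, as for compound 3, remains a real possibility. If a number does appear, the closest reference points are compound 1 at 4020 nM and compound 2 at 5140 nM in the low micromolar region. Compound 4 is expected near 6000 nM, with an estimated range from 1500 nM to 25000 nM in this assay once it is measured.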

Compound 4, half-maximal inhibitory concentration: 13000 nM
The estimate for compound 4 lay 2.2-fold (0.34 log units) below the measured number, and the stated range covers the measured number.
By their numbers in this assay, from the lowest: compounds 1 and 2 (each within the scatter of the next); then compound 4.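

In this assay, 2,4-dihydroxyphenyl on the carbon with a double bond to nitrogen gives a 2.5-fold higher number from compound 2 to compound 4 (0.40 log units; beyond the scatter) and a 3.2-fold higher number from compound 1 to compound 4 (0.51 log units; beyond the scatter), so this position, where the step between the bromo and nitro compounds stayed within the scatter, does respond to a change of group. Compound 3 has no number, so any step from it cannot be read, but compound 4 shows that a phenyl ring carrying two groups can still give a measurable value here, even though compound 3, with its 2,3-dichlorophenyl, was reported as not active. No measurement available here explains why the number rises with 2,4-dihydroxyphenyl.

The compounds shown cannot separate the effect of the hydroxyl groups themselves from that of their placement, since no phenyl ring with a single hydroxyl, or with methoxy groups in those same places, is among them. On these data alone, how an amine or a carboxylic acid on the ring would behave at this position also remains open.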